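Amide Methyl Removal and Substance-P Receptor Binding

The source may hold more compounds than are shown below. What is called first, only, known or untested is meant among the compounds shown, and "the series" means these compounds.

The measured compounds:
compound 1, `Cc1ccccc1-c1c(C(=O)N(C)Cc2cc(C(F)(F)F)cc(C(F)(F)F)c2)n(C)c(=O)c2ccccc12`, 1.3 nM
compound 2, `COc1ccccc1CNC(=O)c1c(-c2ccccc2C)c2ccccc2c(=O)n1C`, 470 nM
compound 3, `COc1ccccc1CN(C)C(=O)c1c(-c2ccccc2C)c2ccccc2c(=O)n1C`, 16 nM

In an assay on IM-9 cells for binding affinity to Substance-P receptor (Homo sapiens) (on this read-out higher numbers stand for weaker inhibition and lower numbers for stronger inhibition), compound 3 gives 16 nM, whereas compound 2 gives 470 nM. The two share a core and differ only by hydrogen in place of methyl on an amide-type nitrogen. This single change produces a 29-fold higher number from compound 3 to compound 2 (1.47 log units; beyond the scatter), a large loss of binding that lies well beyond the usual scatter.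

Compound 1 gives 1.3 nM in this assay, the lowest number of the three and therefore the strongest inhibitor among them. The difference between the core of compound 1 and the core of compound 3 is not broken down here.

Compound 4, `Cc1ccccc1-c1c(C(=O)NCc2cc(C(F)(F)F)cc(C(F)(F)F)c2)n(C)c(=O)c2ccccc12`, has not yet been measured. It differs from compound 1 by hydrogen in place of methyl on an amide-type nitrogen. This is the same change as that from compound 3 to compound 2, and the surroundings of the amide-type nitrogen are the same in both cases.

On that basis compound 4 is expected to bind more weakly than compound 1, with an estimated step of a 23-fold higher number from compound 1 to compound 4 (1.36 log units; beyond the scatter), because the same change gave a 29-fold higher number from compound 3 to compound 2 (1.47 log units; beyond the scatter). The estimate rests on a single precedent, so the uncertainty is wide. Compound 4 is estimated to give 30 nM in this assay, with a likely range from 8 nM to 120 nM.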

Compound 4, half-maximal inhibitory concentration: 2.5 nM
Compound 4: middle estimate off by 12-fold (1.08 log units), on the high side; measured number below the stated range.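

In this assay, hydrogen in place of methyl on the amide-type nitrogen gives a 1.9-fold higher number from compound 1 to compound 4 (0.28 log units; within the scatter), so for this pair the change cannot be told apart from repeat measurement. Within the data shown here, the large loss seen for the same change on the other core therefore did not carry over, and the two steps differ by more than their scatter: the same change on two cores in this assay, a 29-fold higher number (1.47 log units; beyond the scatter) from compound 3 to compound 2 and a 1.9-fold higher number (0.28 log units; within the scatter) from compound 1 to compound 4, 15-fold (1.18 log units) apart, beyond the scatter of two such steps This shows that, in this series, the size of the step seen on one core cannot simply be transferred to another, but with only two pairs it does not show which structural difference between the cores sets that size, nor does it give a rule for any further core.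

The compounds shown leave open what an ethyl group or a longer chain would do on the same amide-type nitrogen, and so whether the contrast between the two cores is confined to the exchange of methyl for hydrogen. They also leave open how the same exchange would behave on a further core, for example one carrying a chlorine or a nitrile in place of the groups found on compound 1 and compound 3.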